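Swapping dimethylamino for bromo in compound 3

The compounds below may be only part of what the source reports. "The series", "measured", "known", "first", "only" and "open" are said of these compounds alone.

Three compounds sharing one core, differing in the group on a carbon with a double bond to nitrogen, have been tested in a functional assay on MCF7 cells (Homo sapiens) for antiproliferative activity, read by MTT assay, with a stated time of 72 h; a lower number here means a stronger inhibitor, a higher number a weaker inhibitor. Compound 2 `CCCSc1nc(N/N=C/c2c[nH]c3ccccc23)c2nnn(Cc3ccccc3)c2n1` gives 9010 nM, and compound 3 `CCCSc1nc(N/N=C/c2ccc(N(C)C)cc2)c2nnn(Cc3ccccc3)c2n1` gives 12200 nM. These two numbers sit close together, as a 1.4-fold higher number from compound 2 to compound 3 (0.13 log units; within the scatter) shows. Compound 1 `CCCSc1nc(N/N=C/c2ccc(Cl)cc2)c2nnn(Cc3ccccc3)c2n1` gives > 64000 nM, which is a limit and not a number.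

Compound 4 `CCCSc1nc(N/N=C/c2ccc(Br)cc2)c2nnn(Cc3ccccc3)c2n1` has not been measured yet. It keeps everything of compound 3 except for one change: bromo in place of dimethylamino on an aromatic carbon. The most relevant measured step is an at least 5.2-fold lower number from compound 1 to compound 3 (0.71 log units; beyond the scatter), where dimethylamino took the place of chloro on an aromatic carbon. The new change runs the opposite way, with bromo standing in for chloro, so the number should rise. A second step, an at least 7.1-fold lower number from compound 1 to compound 2 (0.85 log units; beyond the scatter), also sets the chloro compound apart. Among the measured compounds shown here, no measured compound carries bromo, so treating it like chloro remains an assumption.

A step of a 3.7-fold higher number from compound 3 to compound 4 (0.57 log units; beyond the scatter) is expected, which would lie beyond the scatter. Compound 4 is estimated at 45000 nM, with an expected range from 18000 nM to 110000 nM. It may also return only a limit, as compound 1 did.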

Compound 4, half-maximal inhibitory concentration: > 64000 nM
Compound 4: no number, only a limit; the forecaster's own chance of this, stated with the estimate: 50%; middle value at least 1.4-fold (0.15 log units) away from the limit.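

In this assay, compound 4 gives > 64000 nM, which is a limit and not a number. The earlier compounds shown here showed dimethylamino only against chloro, so the new result adds a second group on the same aromatic carbon: with bromo in place of dimethylamino the result is an at least 5.2-fold higher number from compound 3 to compound 4 (0.71 log units; beyond the scatter), and measured against the indole compound it is an at least 7.1-fold higher number from compound 2 to compound 4 (0.85 log units; beyond the scatter). Chloro and bromo on this carbon now both leave the compounds without a readable number, and the step between compound 1 and compound 4 cannot be read, so any difference between these two groups stays hidden: the limit of > 64000 nM in this assay, at which 2 of the 4 values shown sit.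

The compounds shown do not tell whether the nitrogen of dimethylamino matters or whether other groups on this aromatic carbon would serve as well, and a simple amine, a methoxy group or a carboxylic acid in the same place would help separate these possibilities. On these data alone, how far compound 1 and compound 4 really lie beyond the tested range also remains open, as does whether bromo and chloro would differ in a setting that gives actual numbers.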